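Trifluoromethyl for fluoro on a second aryl piperazine core

This account rests on a few compounds, and the source may have more. Where it says the series, first, only, none or still open, it means among the compounds named here.

Measured so far:
compound 1, `COc1ccc(C(=O)CCN2CCN(c3ccc(F)cc3)CC2)cc1`, 55000 nM
compound 2, `COc1ccc(C(=O)CCN2CCN(c3ccc(C(F)(F)F)cc3)CC2)cc1`, 135000 nM
compound 3, `O=C(CCN1CCN(c2ccc(F)cc2)CC1)c1ccc(Cl)c(F)c1`, 105000 nM

These values come from an ADME assay on Vero cells (Chlorocebus sabaeus) for cytotoxicity, read by resazurin assay, with a stated time of 72 h; a lower number here means a stronger inhibitor, a higher number a weaker inhibitor. Compound 2 differs from compound 1 by trifluoromethyl in place of fluoro on an aromatic carbon, and this change gave a 2.5-fold higher number from compound 1 to compound 2 (0.39 log units; beyond the scatter). Compound 3 differs from compound 1 in its core by 4-chloro-3-fluorophenyl in place of 4-methoxyphenyl on a carbonyl carbon, with a 1.9-fold higher number from compound 1 to compound 3 (0.28 log units; within the scatter). Compound 4, `O=C(CCN1CCN(c2ccc(C(F)(F)F)cc2)CC1)c1ccc(Cl)c(F)c1`, is not yet measured; it differs from compound 3 by trifluoromethyl in place of fluoro on an aromatic carbon, the same kind of change as from compound 1 to compound 2, made on a different core. Because the earlier step was a 2.5-fold higher number from compound 1 to compound 2 (0.39 log units; beyond the scatter), a step of similar size is expected here, estimated at a 2.2-fold higher number from compound 3 to compound 4 (0.34 log units; beyond the scatter). For compound 4 the expected value in this assay is 230000 nM, likely between 110000 nM and 450000 nM.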

Compound 4, half-maximal inhibitory concentration: 74300 nM
Compound 4: the middle estimate sits 3.1-fold (0.49 log units) above what was measured; the measured number lies below the stated range.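

In this assay, trifluoromethyl in place of fluoro gave a 1.4-fold lower number from compound 3 to compound 4 (0.15 log units; within the scatter), so the step seen on the core of compound 1 did not carry over to the second core: the same change on two cores in this assay, a 2.5-fold higher number (0.39 log units; beyond the scatter) from compound 1 to compound 2 and a 1.4-fold lower number (0.15 log units; within the scatter) from compound 3 to compound 4, 3.5-fold (0.54 log units) apart, beyond the scatter of two such steps

Read the other way, 4-chloro-3-fluorophenyl in place of 4-methoxyphenyl gave a 1.8-fold lower number from compound 2 to compound 4 (0.26 log units; within the scatter), so that swap also depends on its partner: the same change on two cores in this assay, a 1.9-fold higher number (0.28 log units; within the scatter) from compound 1 to compound 3 and a 1.8-fold lower number (0.26 log units; within the scatter) from compound 2 to compound 4, 3.5-fold (0.54 log units) apart, beyond the scatter of two such steps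

Both comparisons rest on the same four compounds, so they are one finding seen from two sides: the two changes do not simply add up here, but the data do not show why, or how a third core would behave.

As far as these compounds go, whether a nitrile or an amine in place of the fluoro would depend on the core in the same way remains open. So does whether this pattern would hold in another cell type.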